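The source may hold more compounds than are shown below. What is called first, only, known or untested is meant among the compounds shown, and "the series" means these compounds.

Working notes on the series. Three compounds share a core carrying an ethyl ester, each measured in an assay on COS-7 cells for inhibition of patatin-like phospholipase domain-containing protein 2 (Mus musculus); on this read-out higher numbers stand for weaker inhibition and lower numbers for stronger inhibition. Compound 1 `CCOC(=O)c1cccc(-c2ccc(O)cc2)c1` gives 100000 nM, and compound 3 `CCOC(=O)c1cccc(-c2ccc(CN3CCN(S(C)(=O)=O)CC3)o2)c1` gives 100000 nM, a number that does not differ from compound 1 at the digits reported. Compound 2 `CCOC(=O)c1cccc(-c2ccc3[nH]ccc3c2)c1` gives 60000 nM, which stays within the usual scatter of the value of compound 1, so no ordering among the three is claimed. Among the measured compounds shown here, no step between measured compounds is available to read a direction from. Compound 4 `CCOC(=O)c1cccc(-c2ccc(C(C)=O)cc2)c1` differs from compound 1 by acetyl in place of hydroxy on an aromatic carbon. With nothing in the series to anchor this change, the expected step from compound 1 to compound 4 is a 1.3-fold lower number from compound 1 to compound 4 (0.10 log units; within the scatter), no larger than the scatter. For compound 4 the estimate is 80000 nM, with a range from 25000 nM to 200000 nM.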

Compound 4, half-maximal inhibitory concentration: 200000 nM
Estimate against measurement, compound 4: 2.5-fold (0.40 log units) below; low and high end bracket the measured number.
By their numbers in this assay, from the lowest: compounds 2, 1, 3 and 4 (each within the scatter of the next, the first and the last beyond it).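

In this assay, the series now has its first step at a single position: acetyl in place of hydroxy on an aromatic carbon, para to a large group, gives a 2.0-fold higher number from compound 1 to compound 4 (0.30 log units; within the scatter). The exchange removes the hydrogen-bond donor of hydroxy and adds a carbonyl-bearing group of more heavy atoms, yet the step does not exceed the scatter. This position therefore shows no resolved dependence on this change.

From the compounds shown here alone, whether an amine or a carboxylic acid here would give a step beyond the scatter remains open. Nothing available gives a reason for the step.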